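Lengthening the chain and swapping the terminal group

The compounds below may be only part of what the source reports. "The series", "measured", "known", "first", "only" and "open" are said of these compounds alone.

Of the compounds shown here, three sharing one core have been tested in an assay (Cricetulus griseus) for inhibition of aldehyde dehydrogenase, mitochondrial (Homo sapiens); on this read-out lower numbers stand for stronger inhibition and higher numbers for weaker inhibition. Compound 1 `O=C(O)CCCCOc1ccc2c(=O)c(-c3ccc(O)cc3)coc2c1` gives 100 nM, and compound 2 `C=CCCCCOc1ccc2c(=O)c(-c3ccc(O)cc3)coc2c1` gives 150 nM. Compound 3 `O=c1c(-c2ccc(O)cc2)coc2cc(OCCCCCCCCCCCCO)ccc12` gives 1700 nM, the highest number of the three: the step of an 11-fold higher number from compound 2 to compound 3 (1.05 log units; beyond the scatter) and the step of a 17-fold higher number from compound 1 to compound 3 (1.23 log units; beyond the scatter) both lie beyond the scatter, while the step of a 1.5-fold higher number from compound 1 to compound 2 (0.18 log units; within the scatter) does not.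

Compound 4 `O=C(O)CCCCCCCCCOc1ccc2c(=O)c(-c3ccc(O)cc3)coc2c1` has not yet been measured. The change from compound 3 is carboxy in place of 3-hydroxypropyl on a saturated chain carbon, nine bonds along the chain from an oxygen on an aromatic ring. The measured steps that bear on it all turn on what sits at the far end of the chain. The step of a 17-fold higher number from compound 1 to compound 3 (1.23 log units; beyond the scatter) shows that replacing carboxy with a long hydroxyl-terminated chain raised the number sharply; compound 4 returns a carboxy group to the chain end, though on a longer chain than in compound 1. Among the compounds with values here, a sizeable fall in the number from compound 3 is therefore expected, but not a full return to the number of compound 1, since no measured pair separates chain length from the terminal group. The expected step is a 3.4-fold lower number from compound 3 to compound 4 (0.53 log units; beyond the scatter). Compound 4 is estimated at 500 nM, with a range from 150 nM to 1700 nM.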

Compound 4, half-maximal inhibitory concentration: 50 nM
Beside the measured number, compound 4's estimate is 10-fold (1.00 log units) above it, and the stated range ends above it.
By their numbers in this assay, from the lowest: compounds 4, 1 and 2 (each within the scatter of the next, the first and the last beyond it); then compound 3.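

A long chain on this oxygen is not by itself what gave compound 3 its high number: putting carboxy in place of 3-hydroxypropyl gives a 34-fold lower number from compound 3 to compound 4 (1.53 log units; beyond the scatter), so what stands at the far end of a long chain can carry a large step. Within the data shown here, compound 1 and compound 4 both end in carboxy and so isolate chain length, which the earlier compounds could not do, and 5-carboxypentyl in place of carboxy gives a 2.0-fold lower number from compound 1 to compound 4 (0.30 log units; within the scatter), which means that for this end group the longer chain makes no difference that can be told from the scatter. Against the vinyl-ended chain, the same 5-carboxypentyl group gives a 3.0-fold lower number from compound 2 to compound 4 (0.48 log units; beyond the scatter), a modest step that the shorter carboxy chain did not show over vinyl.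

As far as these compounds go, compound 3 differs from compound 4 in chain length as well as in its end group, so it remains open how a hydroxyl on a chain of exactly the length in compound 4 would read, and whether an amine, an amide or an ester at the chain end would behave like carboxy. Nothing available accounts for the size of these steps.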